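Thiophene attachment point on two dihydropyrimidinone cores

The compounds below may be only part of what the source reports. "The series", "measured", "known", "first", "only" and "open" are said of these compounds alone.

The series is followed in an assay on membranes from HeLa cells for displacement of a labelled ligand from adenosine receptor A3 (Homo sapiens), read by scintillation counting, with a stated time of 180 min, tested at 1 uM; on this read-out higher numbers stand for more inhibition at the one concentration tested (going by the name of the read-out) and lower numbers for less inhibition. Compound 1 `CC1=C(C(=O)OCc2ccccc2)C(c2cccs2)NC(=O)N1` carries a thiophen-2-yl group, and in this assay compound 1 gives 8%. Compound 2 `CC1=C(C(=O)OCc2ccccc2)C(c2ccsc2)NC(=O)N1` differs from it by thiophen-3-yl in place of thiophen-2-yl on a saturated ring carbon and in this assay compound 2 gives 25%. Going by the values given here, the resulting step, a number 17 percentage points higher from compound 1 to compound 2 (beyond the scatter), is the only measured step in the set. Compound 3 `CCSC(=O)C1=C(C)NC(=O)NC1c1cccs1` stands on a second core; the difference between the cores of compound 1 and compound 3 is not broken down here. In this assay compound 3 gives 1%, which lies within the scatter of compound 1 and beyond the scatter from compound 2.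

Compound 4 `CCSC(=O)C1=C(C)NC(=O)NC1c1ccsc1` is not yet measured. It differs from compound 3 by thiophen-3-yl in place of thiophen-2-yl on a saturated ring carbon. This is the same kind of change as that between compound 1 and compound 2, not the same one: in compound 3 the ring atom next to the saturated carbon bears a (ethylsulfanyl)carbonyl group (5 heavy atoms), whereas in compound 1 that ring atom bears a large group.

Because the measured step of a number 17 percentage points higher from compound 1 to compound 2 (beyond the scatter) rose beyond the scatter on the first core, a rise is expected on the second core as well, estimated as a number 13 percentage points higher from compound 3 to compound 4 (beyond the scatter); a single precedent on a different core keeps this expectation loose. For compound 4 the estimated value in this assay is 14%, expected to fall between 2% and 30%.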

Compound 4, a percentage reported as inhibition, at one concentration (the size of the read-out at that concentration, not a potency): 2%
Estimate against measurement, compound 4: 12 percentage points above; low and high end bracket the measured number.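

In this assay, the change from thiophen-2-yl to thiophen-3-yl on a saturated ring carbon does not carry over in size from the core of compound 1 to the core of compound 3: the same change on two cores in this assay, a number 17 percentage points higher (beyond the scatter) from compound 1 to compound 2 and a number 1 percentage points higher (within the scatter) from compound 3 to compound 4, 16 percentage points apart, beyond the scatter of two such steps

On the core of compound 3, the change gives a number 1 percentage points higher from compound 3 to compound 4 (within the scatter), so no effect of the thiophene attachment point can be read on this core, and the step on the core of compound 1 is no guide to it. Going by these compounds alone, with one pair on each core, the data show only that the step depends on the core in these four compounds; they do not show which part of the cores accounts for the gap, or how the step would behave on any third core.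

From the compounds shown here alone, it remains open whether the attachment point matters when the ring atom that bears the (ethylsulfanyl)carbonyl group carries instead a methyl ester, an amide or a longer thioester chain, which could help locate where the two cores part. Also open, going by these compounds, is how a phenyl or a furan ring on the saturated ring carbon would compare with the two thiophenes on either core.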